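Notes on a semicarbazide series: chloro in place of nitro

The source may hold more compounds than are shown below. What is called first, only, known or untested is meant among the compounds shown, and "the series" means these compounds.

Measured compounds:
compound 1, `O=C(N/N=C\c1cccc(O)c1)Nc1nnc(COc2ccc3ccccc3c2)o1`: in a functional assay on the whole organism (strain Swiss albino) with Mus musculus as the target, with a stated time of 4 h (on this read-out lower numbers stand for an effect already at smaller amounts and higher numbers for an effect only at larger amounts of compound), compound 1 gives 300 mg/kg
compound 2, `C/C(=N/NC(=O)Nc1nnc(COc2ccc3ccccc3c2)o1)c1ccc([N+](=O)[O-])cc1`: in this assay compound 2 gives 300 mg/kg
compound 3, `O=C(N/N=C(/c1ccccc1)c1ccc([N+](=O)[O-])cc1)Nc1nnc(COc2ccc3ccccc3c2)o1`: in this assay compound 3 gives 300 mg/kg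

Compound 2 stands level with compounds 1 and 3 at the digits shown; the values of compound 1 and compound 3 are within the scatter of that of compound 2. Going by the values given here, the only step between compounds that differ in one place, no change at the digits printed from compound 2 to compound 3 (within the scatter), brings phenyl in place of methyl on a carbon with a double bond to nitrogen and leaves the read-out unchanged within the scatter.

Compound 4, `C/C(=N/NC(=O)Nc1nnc(COc2ccc3ccccc3c2)o1)c1ccc(Cl)cc1`, is not yet measured. It differs from compound 2 by chloro in place of nitro on an aromatic carbon. Among the compounds with values here, no measured step touches this kind of change, so nothing speaks for a shift in either direction; the one step that is known shows the read-out tolerating a change elsewhere without moving. The expectation for compound 4 is therefore no step beyond the scatter, no change at the digits printed from compound 2 to compound 4 (within the scatter). Compound 4 is thus estimated at 300 mg/kg in this assay, with a range from 150 mg/kg to 600 mg/kg.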

Compound 4, minimum effective dose: 300 mg/kg
For compound 4 middle estimate and measured number coincide at the digits printed; the measured number falls inside the stated range.
By their numbers in this assay, from the lowest: compounds 1, 2, 3 and 4 (each within the scatter of the next).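

In this assay, going by these compounds alone, chloro in place of nitro on an aromatic carbon gives no change at the digits printed from compound 2 to compound 4 (within the scatter), the first reading of any change on this ring; para to a large group, the read-out therefore does not depend on nitro, since chloro serves equally well here. The larger exchange on the amide-type nitrogen, a group of 10 heavy atoms in place of a group of 9 heavy atoms, gives no change at the digits printed from compound 1 to compound 4 (within the scatter), so the change of the whole group there also leaves the read-out in place. No measurement is available that bears on this flat result.

On these data alone, all four compounds stand at one level, so it remains unknown which change, if any, would move the read-out at all. Open, as far as these compounds go, are an amine or a carboxylic acid on this aromatic carbon, and a longer chain in place of methyl on the carbon with a double bond to nitrogen.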